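A few compounds are considered here, and "the series" means these few. Any claim that something is new, unique, unknown or untested is made for them only; others in the source may bear on it.

Compound 3 `CC(=O)c1ccc(NC(=O)C(CC(C)C)N(C(=O)c2ccccc2)S(=O)(=O)c2ccccc2)cc1` is one of three related compounds that have been measured in a functional assay for inhibition, read by spectrophotometry, with a stated time of 20 min, tested at 3 mg/mL; on this read-out higher numbers stand for a stronger effect at the one concentration tested and lower numbers for a weaker effect. In this assay compound 3 gives 40.7%. Compound 2 `CC(=O)c1ccc(NC(=O)CN(C(=O)c2ccccc2)S(=O)(=O)c2ccccc2)cc1` gives 40.7%, and compound 1 `CC(=O)c1ccc(NC(=O)C(C(C)C)N(C(=O)c2ccccc2)S(=O)(=O)c2ccc(C)cc2)cc1` gives 29.7%. Compound 3 therefore sits level with compound 2 at the digits shown, the two together forming the highest pair of the three, while compound 1 lies lower by more than the usual scatter of this kind of measurement.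

Among the compounds with values here, compound 4 `CC(=O)c1ccc(NC(=O)C(C(C)C)N(C(=O)c2ccccc2)S(=O)(=O)c2ccccc2)cc1` has not yet been measured. isopropyl in place of isobutyl on a saturated chain carbon bound to an amide-type nitrogen and a carbonyl carbon Only one measured step touches this same position: no change at the digits printed from compound 2 to compound 3 (within the scatter), so adding the isobutyl in place of hydrogen made no difference beyond the scatter. Within the data shown here, the only other measured compound carrying isopropyl at this position is compound 1, which also differs from compound 4 in a second place, so its lower reading is a hint rather than a direct comparison. On this basis the expected step is small, a number 4.7 percentage points lower from compound 3 to compound 4 (within the scatter), leaning slightly downward but quite possibly within the scatter. Compound 4 is estimated to give 36% in this assay, with a likely range from 24% to 48%.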

Compound 4, a percentage reported as inhibition, at one concentration (the size of the read-out at that concentration, not a potency): 47.5%
Compound 4: the middle estimate sits 11.5 percentage points below what was measured; the range from low to high includes it.
By their numbers in this assay, from the lowest: compound 1; then compounds 2, 3 and 4 (each within the scatter of the next).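

At the saturated chain carbon bound to an amide-type nitrogen and a carbonyl carbon, hydrogen, isobutyl and isopropyl now read alike in this assay: replacing isobutyl with isopropyl gives a number 6.8 percentage points higher from compound 3 to compound 4 (within the scatter) and replacing hydrogen with isopropyl gives a number 6.8 percentage points higher from compound 2 to compound 4 (within the scatter) in the same assay. This position has therefore accepted all three groups without any change beyond the scatter, so neither the presence of a branched chain nor its exact shape shows up in this read-out. The one clear difference lies elsewhere, on an aromatic carbon, where hydrogen in place of methyl gives a number 17.8 percentage points higher from compound 1 to compound 4 (beyond the scatter) and so ties the lower reading of compound 1 to that methyl rather than to its isopropyl.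

From the compounds shown here alone, it remains open how an amine, a carboxylic acid or a chain longer than isobutyl would read at the chain carbon, and whether removing the aromatic methyl has the same effect when isobutyl or hydrogen sits there. No measurement shown here explains these readings.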